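A few compounds are considered here, and "the series" means these few. Any claim that something is new, unique, unknown or untested is made for them only; others in the source may bear on it.

Compound 1 `Cc1ccc(S(=O)(=O)Nc2ccc(-c3nc4ccccc4o3)cc2)cc1` — in an assay on isolated protein for inhibition of malate dehydrogenase, mitochondrial (Sus scrofa), with stated times of 45 min and 30 min (on this read-out higher numbers stand for weaker inhibition and lower numbers for stronger inhibition), compound 1 gives > 63000 nM, which is a limit of the assay rather than a number.
Compound 2 `C=Cc1ccc(S(=O)(=O)Nc2ccc3oc(-c4ccccc4)nc3c2)cc1` — compound 2 gives > 63000 nM, likewise a limit of the assay.
Compound 3 `O=S(=O)(Nc1ccc(-c2nc3ccccc3o2)cc1)c1cccc(Cl)c1` — compound 3 gives > 63000 nM, again a limit of the assay.

Among the compounds with values here, compound 2 therefore stands only at a limit, and the two further values shown are limits as well, so no measured compound can be placed above or below another. Within the data shown here, the one step between measured compounds, a step that the two limits leave unreadable from compound 1 to compound 3, cannot be read in size because both of its ends sit at the limit of > 63000 nM in this assay, at which 3 of the 3 values shown sit.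

Compound 4 `O=S(=O)(Nc1ccc2oc(-c3ccccc3)nc2c1)c1cccs1` differs from compound 2 in one place: thiophen-2-yl in place of 4-vinylphenyl on a sulfonyl sulfur. No measured step bears on this change; the only step shown is unreadable, and nothing among the three values points to a difference between one sulfonyl substituent and another. The expectation for the step from compound 2 to compound 4 is accordingly no readable change, with compound 4 expected to remain at the limit, as a step that the limit leaves unreadable from compound 2 to compound 4 expresses. Compound 4 is estimated in this assay at 100000 nM, with a range from 30000 nM to 400000 nM, and the result is expected most likely to be reported as a limit again.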

Compound 4, half-maximal inhibitory concentration: > 63000 nM
Compound 4: only a limit was reported; the forecaster's own chance of this, stated with the estimate: 85%; the middle value does not contradict the limit.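

Within the data shown here, the change from compound 2 to compound 4 gives no step that can be read, as both compounds sit at a limit in this assay: the limit of > 63000 nM in this assay, at which 4 of the 4 values shown sit. The compounds shown leave open whether any sulfonyl substituent or any change to the core gives a numerical value in this assay.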